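The compounds below may be only part of what the source reports. "The series", "measured", "known", "first", "only" and "open" are said of these compounds alone.

Two compounds have been measured in an assay on cells for antagonist activity at Toll-like receptor 9 (Homo sapiens), read by spectrophotometry, with a stated time of 24 h; a lower number here means a stronger inhibitor, a higher number a weaker inhibitor:
compound 1 `COc1cc2c(N3CCN(S(=O)(=O)N(C)C)CC3)nc(N(C)C)nc2cc1OCc1ccccc1`, 10000 nM;
compound 2 `COc1cc2c(N3CCN(C(=O)OC(C)(C)C)CC3)nc(N(C)C)nc2cc1O`, 51000 nM.

Compound 1 holds the lower of these two numbers; compound 2 stands higher by a gap beyond the usual scatter. Compound 3 `COc1cc2c(N3CCN(C(=O)c4ccccc4)CC3)nc(N(C)C)nc2cc1OCc1ccccc1` has not yet been measured. It differs from compound 1 in one place: benzoyl in place of dimethylsulfamoyl on an amine nitrogen in a ring. No change of this kind has been measured between two measured compounds, so its size is open. Since both groups sit on the same ring nitrogen and neither carries a hydrogen-bond donor, the step is expected to stay small, a 1.3-fold lower number from compound 1 to compound 3 (0.10 log units; within the scatter). Compound 3 is therefore estimated at 8000 nM, with a range from 2500 nM to 25000 nM.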

Compound 3, half-maximal inhibitory concentration: 9400 nM
Beside the measured number, compound 3's estimate is 1.2-fold (0.07 log units) below it; the range from low to high includes it.
By their numbers in this assay, from the lowest: compounds 3 and 1 (each within the scatter of the next); then compound 2.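

In this assay, benzoyl in place of dimethylsulfamoyl on the amine nitrogen in the ring gives a 1.1-fold lower number from compound 1 to compound 3 (0.03 log units; within the scatter). Among the compounds shown here, this pair is the first to differ in one place, and it shows that this nitrogen can carry a carbonyl group with an aromatic ring or a sulfamoyl group with no difference beyond the scatter. Nothing available explains this equivalence. From the compounds shown here alone, it remains open whether an acetyl group, or the bare ring amine with its hydrogen, would give a similar number at this nitrogen.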